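A few compounds are considered here, and "the series" means these few. Any claim that something is new, unique, unknown or untested is made for them only; others in the source may bear on it.

In a functional assay on TK-10 cells (Homo sapiens) for inhibition, read by sulforhodamine B assay, with a stated time of 48 h (on this read-out higher numbers stand for weaker inhibition of growth and lower numbers for stronger inhibition of growth), compound 1 `CN1CCN(CCCOc2cccc3nc(Nc4ccc(Cl)c(F)c4)ccc23)CC1` gives 1810 nM and shares the low end of the three measured numbers with compound 3 `CN1CCN(CCCOc2cccc3nc(Nc4ccc(F)c(F)c4)ccc23)CC1` at 2630 nM while compound 2 `CC(C)c1ccc(Nc2ccc3c(OCCCN4CCN(C)CC4)cccc3n2)cc1` stands clear of both at 16500 nM in the same read-out. Compound 4 `CN1CCN(CCCOc2cccc3nc(Nc4cccc(Cl)c4)ccc23)CC1` is still unmeasured. It differs from compound 1 in one place, 3-chlorophenyl in place of 4-chloro-3-fluorophenyl on a nitrogen on an aromatic ring with 3-chlorophenyl in place of 4-chloro-3-fluorophenyl on a nitrogen on an aromatic ring. The closest measured step is a 1.5-fold higher number from compound 1 to compound 3 (0.16 log units; within the scatter) for fluoro in place of chloro on an aromatic carbon, so one halogen exchange on this group left the number within the scatter. The larger steps of a 9.1-fold higher number from compound 1 to compound 2 (0.96 log units; beyond the scatter) and a 6.3-fold lower number from compound 2 to compound 3 (0.80 log units; beyond the scatter) both involve 4-isopropylphenyl, which compound 4 does not carry. Going by the values given here, they show that the group on that nitrogen can shift the number, but no measured step removes a halogen alone. A small upward step is therefore expected in this assay and none beyond the scatter. The estimate is a 1.4-fold higher number from compound 1 to compound 4 (0.14 log units; within the scatter) and is expected to stay within the scatter. The expected value for compound 4 is 2500 nM with an estimated range (1100 nM to 6000 nM).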

Compound 4, concentration for 50% growth inhibition: 1670 nM
Beside the measured number, compound 4's estimate is 1.5-fold (0.18 log units) above it; the measured number falls inside the stated range.
By their numbers in this assay, from the lowest: compounds 4, 1 and 3 (each within the scatter of the next); then compound 2.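

In this assay, the 3-chlorophenyl group in place of the 4-chloro-3-fluorophenyl group on the nitrogen gives a 1.1-fold lower number from compound 1 to compound 4 (0.03 log units; within the scatter), so a group carrying one halogen fewer stays within the scatter here, just as the earlier exchange of one halogen for another did. With a 1.6-fold lower number from compound 3 to compound 4 (0.20 log units; within the scatter) added, the three halogen-bearing phenyl groups of compound 1, compound 3 and compound 4 all lie within the scatter of one another, and a 9.9-fold lower number from compound 2 to compound 4 (0.99 log units; beyond the scatter) sets the 4-isopropylphenyl group of compound 2 apart from this new member as well, so among these four compounds only the 4-isopropylphenyl group gives a step beyond the scatter. Nothing at hand accounts for why the numbers fall this way.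

The compounds shown leave open whether a plain phenyl group with no halogen at all would sit with the three halogen-bearing compounds or with compound 2, which would tell whether any halogen is needed on this ring. They also leave open how a methoxy group, an amine or a carboxylic acid on that ring would read, and what a longer chain to the methylpiperazine would do.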